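Methoxy entering a new place on the core of compound 1

The compounds below may be only part of what the source reports. "The series", "measured", "known", "first", "only" and "open" are said of these compounds alone.

Compound 1 `C[S+]([O-])/C=C/c1cc(=O)c2ccccc2o1` is tested in a functional assay on A549 cells (Homo sapiens) for cytotoxicity, with a stated time of 48 h (on this read-out lower numbers stand for stronger inhibition and higher numbers for weaker inhibition), where compound 1 gives 1900 nM. Compound 2 `Cc1cccc2oc(/C=C/[S+](C)[O-])cc(=O)c12` gives 1300 nM and compound 3 `COc1cccc2c(=O)cc(/C=C/[S+](C)[O-])oc12` gives 2200 nM; compound 1 lies within the scatter of both, nearest to compound 3. The two substitutions on the core so far give a 1.5-fold lower number from compound 1 to compound 2 (0.16 log units; within the scatter) and a 1.2-fold higher number from compound 1 to compound 3 (0.06 log units; within the scatter), neither moving the read-out beyond the scatter. Compound 4 `COc1ccc2oc(/C=C/[S+](C)[O-])cc(=O)c2c1` differs from compound 1 by methoxy in place of hydrogen on an aromatic carbon. The closest comparison is the same group entering elsewhere on the core, the flat step from compound 1 to compound 3 of a 1.2-fold higher number from compound 1 to compound 3 (0.06 log units; within the scatter). Expected, therefore, is a 1.1-fold higher number from compound 1 to compound 4 (0.02 log units; within the scatter). For compound 4 the estimate is 2000 nM, with a range from 900 nM to 4500 nM.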

Compound 4, half-maximal inhibitory concentration: 1600 nM
Compound 4: the middle estimate sits 1.3-fold (0.10 log units) above what was measured, within the range that was stated.
By their numbers in this assay, from the lowest: compounds 2, 4, 1 and 3 (each within the scatter of the next).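

Methoxy at this further place on the core, an aromatic carbon meta to a fused ring and para to a fused ring, gives a 1.2-fold lower number from compound 1 to compound 4 (0.07 log units; within the scatter) in this assay. Among these compounds, this position therefore joins the one in compound 3 as a second place where methoxy leaves the number within the scatter of compound 1. No measurement bears on why this step stays so small.

Open is whether an amine or a carboxylic acid at this position would move the number beyond the scatter, since only methoxy is shown here.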